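The source may report more compounds than this note shows. Statements on the series, on what has been measured and on what is new or still open speak of the compounds shown alone.

Measured so far:

compound 1 `COc1ccc(/C=C2\N=C(c3ccc(C)cc3)N(C(=O)c3nc4c(c(C)nn4-c4ccccc4)c(=O)[nH]3)NC2=O)cc1` — 36.8 nM
compound 2 `Cc1nn(-c2ccccc2)c2nc(C(=O)N3NC(=O)/C(=C/c4ccccc4)N=C3c3ccccc3)[nH]c(=O)c12` — 49.5 nM
compound 3 `Cc1nn(-c2ccccc2)c2nc(C(=O)N3NC(=O)/C(=C/c4ccc(Cl)cc4)N=C3c3ccc(Cl)cc3)[nH]c(=O)c12` — 19.3 nM

In an ADME assay on WI-38 cells (Homo sapiens) for cytotoxicity, read by MTT assay, with a stated time of 48 h (a higher number here means a weaker inhibitor, a lower number a stronger inhibitor), compound 1 gives 36.8 nM, the second highest of the three numbers. Compound 2 gives 49.5 nM in this assay, and compound 3 gives 19.3 nM; the differences from compound 1 to each of these lie within the scatter, so no order between compound 1 and either of them can be read from the numbers.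

Compound 4 `COc1ccc(/C=C2\N=C(c3ccccc3)N(C(=O)c3nc4c(c(C)nn4-c4ccccc4)c(=O)[nH]3)NC2=O)cc1` is the next candidate for this assay. It differs from compound 1 in one place: hydrogen in place of methyl on an aromatic carbon, which, cut one bond further out, reads 4-methylphenyl to phenyl. Going by the values given here, no measured pair isolates this change; compound 2 also carries the plain phenyl, but it differs from compound 1 elsewhere as well, so no step for the methyl alone is known. With nothing to point either way, the step is expected to stay within the scatter, if anything leaning toward a slightly higher number.

For compound 4 in this assay the estimate is 42 nM, with a range from 20 nM to 90 nM, which means an expected step of a 1.1-fold higher number from compound 1 to compound 4 (0.06 log units; within the scatter).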

Compound 4, half-maximal inhibitory concentration: 97.7 nM
Compound 4: the middle estimate sits 2.3-fold (0.37 log units) below what was measured, and the stated range ends below it.
By their numbers in this assay, from the lowest: compounds 3, 1, 2 and 4 (each within the scatter of the next, the first and the last beyond it).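

In this assay, going from 4-methylphenyl to phenyl gives a 2.7-fold higher number from compound 1 to compound 4 (0.42 log units; beyond the scatter). Going by these compounds alone, this is the first single-place step, and it lies beyond the scatter, so the methyl on this aromatic carbon is not silent here, though the effect is modest and rests on one pair. Methoxy in place of hydrogen on an aromatic carbon gives a 2.0-fold higher number from compound 2 to compound 4 (0.30 log units; within the scatter), which stays within the scatter, and no data on these compounds offer an explanation for either step.

On these data alone, the methyl step is known only in the presence of the methoxy group of compound 1, so whether it holds without that group remains open. Also open, as far as these compounds go, is how this carbon would respond to an ethyl group, a fluorine atom or an amine in place of the methyl.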